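Moving the acid and the chlorine on an ether-linked aryl

A few compounds are considered here, and "the series" means these few. Any claim that something is new, unique, unknown or untested is made for them only; others in the source may bear on it.

Three compounds share a core with a branched ketone and a phenol, joined through an ether to a short chain that carries a second aromatic ring bearing a carboxylic acid. Compound 1 `Cc1c(OCCCCOc2ccc(Cl)c(C(=O)O)c2)ccc(C(=O)CC(C)(C)C)c1O` carries a butyl chain to a 4-chloro-3-carboxyphenyl group; in an assay for positive allosteric modulation of metabotropic glutamate receptor 3 (Rattus norvegicus) (a higher number here means that more compound is needed for the effect, a lower number that less compound is needed), compound 1 gives 130 nM. Compound 2 `Cc1ccc(OC[C@H](C)COc2ccc(C(=O)CC(C)(C)C)c(O)c2C)cc1C(=O)O` has a branched 2-methylpropyl chain and a 3-carboxy-4-methylphenyl group. For compound 2 this assay returned only a limit, > 10000 nM, not a number, so compound 2 sits at the upper edge of what the assay can report (the limit of > 10000 nM in this assay, at which 1 of the 2 values shown sits). Compound 3 `Cc1c(OC[C@@H](C)COc2ccc(C(=O)O)cc2Cl)ccc(C(=O)CC(C)(C)C)c1O` keeps the branched chain of compound 2 and changes the outer ring: 4-carboxy-2-chlorophenyl in place of 3-carboxy-4-methylphenyl on an oxygen on a saturated carbon. Because compound 2 stands at a limit > 10000 nM, the size of this step can only be guessed from a bound. Compound 3 is expected to gain some potency, by an estimated at least 3.3-fold lower number from compound 2 to compound 3 (0.52 log units; beyond the scatter), though a result at the limit again remains quite possible. Compound 3 is estimated at 3000 nM, within a range from 500 nM to 10000 nM.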

Compound 3, half-maximal effective concentration: 1650 nM
Compound 3: middle estimate off by 1.8-fold (0.26 log units), on the high side, and the stated range covers the measured number.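

In this assay compound 2 stands at > 10000 nM, which is a limit and not a number. With the rest of the molecule unchanged, placing 4-carboxy-2-chlorophenyl on an oxygen on a saturated carbon, in place of 3-carboxy-4-methylphenyl, gives an at least 6.0-fold lower number from compound 2 to compound 3 (0.78 log units; beyond the scatter), so this outer ring alone is enough to turn a result at the limit into a readable value on the branched chain. The step is only a lower bound on the real gain, because one end of it is not a true number: the limit of > 10000 nM in this assay, at which 1 of the 3 values shown sits.

The swap changes two things at once, as the carboxy group moves from the 3 to the 4 in the group's name and a chlorine enters while a methyl leaves, so the compounds shown cannot say which of these accounts for the gain. As far as these compounds go, a 4-carboxy-2-methylphenyl group on the same chain would help to separate the two, and it remains open whether a fluorine or a nitrile could stand in for the chlorine, or an amide for the carboxylic acid.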